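The source may report more compounds than this note shows. Statements on the series, on what has been measured and on what is new or still open speak of the compounds shown alone.

Measured compounds in an assay on isolated protein for inhibition of serine/threonine-protein kinase PAK 4 (Homo sapiens), read by HTRF, with a stated time of 60 min; on this read-out higher numbers stand for weaker inhibition and lower numbers for stronger inhibition:
- compound 1 `Cc1cc(Nc2nc(NCc3ccccc3F)nc3[nH]ncc23)n[nH]1`, value 389 nM
- compound 2 `Cc1cc(Nc2nc(NCc3ccccc3Br)nc3[nH]ncc23)n[nH]1`, value 1090 nM
- compound 3 `Cc1cc(Nc2nc(NCc3ccc(F)cc3)nc3[nH]ncc23)n[nH]1`, value 395 nM

Compound 2 carries the highest number of the three; its distance to each of the others is beyond the scatter. For the measured compounds named here, two measured steps bear on the present change: a 2.8-fold higher number from compound 1 to compound 2 (0.45 log units; beyond the scatter) and a 2.8-fold lower number from compound 2 to compound 3 (0.44 log units; beyond the scatter). Going by the values given here, both place the 2-bromophenyl compound modestly above either fluorophenyl analogue, while a 1.0-fold higher number from compound 1 to compound 3 (0.01 log units; within the scatter) shows that moving the single fluorine gives no step of note. Compound 4 `Cc1cc(Nc2nc(NCc3ccc(F)cc3F)nc3[nH]ncc23)n[nH]1` differs from compound 2 as follows: 2,4-difluorophenyl in place of 2-bromophenyl on a saturated chain carbon bound to a nitrogen on an aromatic ring. Since compound 4 carries fluorine in both places already covered by compound 1 and compound 3, a modest fall in this assay, about the size of a 2.8-fold lower number from compound 2 to compound 3 (0.44 log units; beyond the scatter), is expected. Compound 4 is therefore estimated at 380 nM, with a range of 180 nM to 800 nM. This corresponds to an expected 2.9-fold lower number from compound 2 to compound 4 (0.46 log units; beyond the scatter).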

Compound 4, half-maximal inhibitory concentration: 96.1 nM
For compound 4 the middle estimate is 4.0-fold (0.60 log units) above the measured one; the whole stated range lies above it.
By their numbers in this assay, from the lowest: compound 4; then compounds 1 and 3 (each within the scatter of the next); then compound 2.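

In this assay, for the compounds shown here, the 2,4-difluorophenyl group gives more than either single fluorine: a 4.0-fold lower number from compound 1 to compound 4 (0.61 log units; beyond the scatter) and a 4.1-fold lower number from compound 3 to compound 4 (0.61 log units; beyond the scatter) show that fluoro in place of hydrogen still pays on both monofluorinated compounds, although moving the lone fluorine gave no step of note. Against the 2-bromophenyl group the change reaches an 11-fold lower number from compound 2 to compound 4 (1.05 log units; beyond the scatter), the only large step in the series, and compound 4 now has the lowest number of the four. Nothing available accounts for this gain.

Open, as far as these compounds go, is whether other groups on this ring, such as chloro, methoxy or an amine, match the two fluorines. Also open, from the compounds shown here alone, is whether the gain survives a longer chain to the ring.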